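This account rests on a few compounds, and the source may have more. Where it says the series, first, only, none or still open, it means among the compounds named here.

Measured compounds in a functional assay on KBVIN cells (Homo sapiens) for antiproliferative activity, read by sulforhodamine B assay, with a stated time of 3 days; on this read-out lower numbers stand for an effect already at smaller amounts and higher numbers for an effect only at larger amounts of compound:

compound 1, `CCC1=C(O)c2c(oc(-c3ccc(F)cc3)cc2=O)C(CC)(CC)C1=O`, gives 1.85 uM
compound 2, `CCC1=C(O)c2c(oc(-c3cccc(OC)c3)cc2=O)C(CC)(CC)C1=O`, gives 1.22 uM
compound 3, `CCC1=C(O)c2c(oc(-c3ccc(C)c(F)c3)cc2=O)C(CC)(CC)C1=O`, gives 2.95 uM

Compound 3 has the highest of the three numbers in this assay. Its nearest neighbour is compound 1, where the step of a 1.6-fold higher number from compound 1 to compound 3 (0.20 log units; within the scatter) lies within the scatter; its furthest is compound 2, where the step of a 2.4-fold higher number from compound 2 to compound 3 (0.38 log units; beyond the scatter) is modest but beyond the scatter. The step from compound 1 to compound 2, a 1.5-fold lower number from compound 1 to compound 2 (0.18 log units; within the scatter), lies within the scatter.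

Compound 4, `CCC1=C(O)c2c(oc(-c3cc(C)ccc3C)cc2=O)C(CC)(CC)C1=O`, differs from compound 3 in one place: 2,5-dimethylphenyl in place of 3-fluoro-4-methylphenyl on an aromatic carbon. Among the measured compounds shown here, no measured step exchanges one substituted phenyl ring for another of this kind, so the three measured exchanges on the same aromatic carbon are the only guide, and all of them moved the number by a small or modest amount. The step is therefore expected to be small, with no clear direction, and is estimated as a 1.2-fold lower number from compound 3 to compound 4 (0.07 log units; within the scatter). Compound 4 is expected to give 2.5 uM in this assay, within a range from 1 uM to 6 uM.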

Compound 4, concentration for half-maximal effect: 3.41 uM
Compound 4: middle estimate off by 1.4-fold (0.13 log units), on the low side; measured number inside the range.
By their numbers in this assay, from the lowest: compounds 2, 1, 3 and 4 (each within the scatter of the next, the first and the last beyond it).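

In this assay, the exchange of 3-fluoro-4-methylphenyl for 2,5-dimethylphenyl gives a 1.2-fold higher number from compound 3 to compound 4 (0.06 log units; within the scatter), so a ring substituent made of carbon only, with the fluorine gone and a second methyl group in its place, leaves the number at this aromatic carbon next to the ring oxygen within the scatter of compound 3. The same holds against the 4-fluorophenyl group, with a 1.8-fold higher number from compound 1 to compound 4 (0.27 log units; within the scatter), whereas the 3-methoxyphenyl group stands apart with a 2.8-fold higher number from compound 2 to compound 4 (0.45 log units; beyond the scatter), a modest step that matches compound 2's separation from compound 3 but not from compound 1. No available evidence accounts for these differences.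

Going by these compounds, all four compounds carry a substituted phenyl ring here, so the effect of a pyridine ring or a small alkyl chain at this carbon remains open. On these data alone, it is also open whether an amine or a carboxylic acid on the phenyl ring would move the number further than these groups do.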